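The source may hold more compounds than are shown below. What is called first, only, known or untested is meant among the compounds shown, and "the series" means these compounds.

Compound 1 `O=C(Nc1cccc(-n2cc(-c3ccncc3)c(-c3ccc(Cl)c(O)c3)n2)c1)Nc1cccc(C(F)(F)F)c1` gives in a functional assay on COLO 205 cells (Homo sapiens) for inhibition, read by sulforhodamine B assay, with a stated time of 48 h (a lower number here means that less compound is tolerated, a higher number that more compound is tolerated), only a limit, > 32500 nM.
Compound 2 `O=C(Nc1cccc(-n2cc(-c3ccncc3)c(-c3ccc(Cl)c(O)c3)n2)c1)Nc1ccc(Cl)c(Cl)c1` gives in this assay 22700 nM.
Compound 3 `COc1cc(-c2nn(-c3cccc(NC(=O)Nc4ccc(Cl)c(C(F)(F)F)c4)c3)cc2-c2ccncc2)ccc1Cl` gives in this assay 3480 nM.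

Among these numbers compound 3 stands lowest: compound 2 is its nearest neighbour, and the gap from compound 3 to compound 2 lies beyond the scatter. For compound 1 only a limit is known, (the limit of > 32500 nM in this assay, at which 1 of the 3 values shown sits), so it sits outside any ranking. Among the compounds with values here, the sole step between measured compounds, an at least 1.4-fold lower number from compound 1 to compound 2 (0.15 log units; that floor lies within the scatter), concerns the aryl on the urea and not the part of the molecule that changes next.

Compound 4 `O=C(Nc1cccc(-n2cc(-c3ccncc3)c(-c3ccc(Cl)c(O)c3)n2)c1)Nc1ccc(Cl)c(C(F)(F)F)c1` is compound 3 with a single change: hydrogen in place of methyl on an oxygen on an aromatic ring. Within the data shown here, no measured pair differs in exactly this way, so the size of the step has to be guessed. Compound 1 and compound 2 both carry the hydroxy group and tolerate far more compound than compound 3, but they also carry other aryl groups on the urea, so their values cannot be laid on this change alone.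

Compound 4 is therefore expected to give 8000 nM in this assay, within a range of 2500 nM to 30000 nM. The expected step is a 2.3-fold higher number from compound 3 to compound 4 (0.36 log units; beyond the scatter), a modest rise that may well fall within the scatter.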

Compound 4, concentration lethal to 50% of the cells: 16100 nM
The estimate for compound 4 lay 2.0-fold (0.30 log units) below the measured number; the measured number falls inside the stated range.
By their numbers in this assay, from the lowest: compound 3; then compounds 4 and 2 (each within the scatter of the next). At a limit, above all of these: compound 1.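

Replacing methoxy with hydroxy is now measured directly, with the aryl on the urea held the same: in this assay the change gives a 4.6-fold higher number from compound 3 to compound 4 (0.67 log units; beyond the scatter), so more compound is tolerated with the hydroxy group. With the hydroxy group kept, trifluoromethyl in place of chloro on the urea aryl gives a 1.4-fold lower number from compound 2 to compound 4 (0.15 log units; within the scatter), so compound 2 and compound 4 cannot be told apart, and this swap shows no effect of the size seen for the methoxy change. The step for chloro in place of hydrogen, an at least 2.0-fold lower number from compound 1 to compound 4 (0.30 log units; that floor lies within the scatter), starts from compound 1, whose value is only a limit: the limit of > 32500 nM in this assay, at which 1 of the 4 values shown sits.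

The compounds shown carry only methoxy or hydroxy at this place on the aromatic ring, so what an ethoxy group, an amine or a carboxylic acid would do there stays open. A single pair also cannot show why the number rises, or whether the same step would appear with the 3-(trifluoromethyl)phenyl or 3,4-dichlorophenyl group on the urea.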